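The source may hold more compounds than are shown below. What is called first, only, known or untested is meant among the compounds shown, and "the series" means these compounds.

Within the data shown here, compound 1, with the structure `CC(C)C(c1ccc(-c2ccc3cccc(F)c3c2)[nH]c1=O)C1C(=O)NC(=O)N1C`, is one of two compounds measured in an assay on membranes from Chem-1 cells for displacement of a labelled ligand from prostaglandin E2 receptor EP3 subtype (Homo sapiens), read by scintillation counting, with a stated time of 2 h; a lower number here means a stronger inhibitor, a higher number a weaker inhibitor. In this assay compound 1 gives 46 nM, the highest of the two numbers recorded. The other measured compound, compound 2, has the structure `CC(C)[C@H](C[C@@H]1OC(=O)NC1=O)c1ccc(-c2ccc3cccc(F)c3c2)[nH]c1=O` and gives 8 nM in this assay; the two compounds differ in more than one place, so their values can only be set side by side, and compound 2 shows the stronger binding by a margin beyond the usual scatter.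

Compound 3, with the structure `CC(C)C(CC1C(=O)NC(=O)N1C)c1ccc(-c2ccc3cccc(F)c3c2)[nH]c1=O`, has not yet been measured. It differs from compound 1 in a single place: (3-methyl-2,5-dioxoimidazolidin-4-yl)methyl in place of 3-methyl-2,5-dioxoimidazolidin-4-yl on a saturated chain carbon bound to an aromatic carbon and a saturated chain carbon. The ring that carries the two carbonyls and the methylated nitrogen is thus pushed one carbon further from the chain carbon that sits on the core.

Because compound 2, which also carries its ring on a one-carbon link, gives 8 nM, the step in this assay is expected to run toward a lower number, of moderate size: a 3.1-fold lower number from compound 1 to compound 3 (0.49 log units; beyond the scatter). Compound 3 is therefore estimated at 15 nM, within a range from 5 nM to 50 nM.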

Compound 3, inhibition constant: 17 nM
Compound 3: the middle estimate sits 1.1-fold (0.05 log units) below what was measured; the range from low to high includes it.
By their numbers in this assay, from the lowest: compound 2; then compound 3; then compound 1.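

Among these compounds, this is the first comparison in which only the link to the ring changes, so it isolates the effect of that link. In this assay, moving from 3-methyl-2,5-dioxoimidazolidin-4-yl to (3-methyl-2,5-dioxoimidazolidin-4-yl)methyl on the saturated chain carbon gives a 2.7-fold lower number from compound 1 to compound 3 (0.43 log units; beyond the scatter), which shows that binding at this position responds to the distance of the ring from that chain carbon, even though the ring itself stays the same and the counts of hydrogen-bond donors and acceptors do not change. No separate measurement is available to explain why the added carbon gives the lower number.

With only these two link lengths compared, the compounds shown leave open whether a longer chain carrying the same ring would lower the number further or raise it again. They also leave open whether the ring is needed at all on this link, which a carboxylic acid or an amine in its place could test in this assay against the value of compound 3, 17 nM.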